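Replacing the 1,3-oxazol-2-yl group of compound 1

This account rests on a few compounds, and the source may have more. Where it says the series, first, only, none or still open, it means among the compounds named here.

Among the measured compounds shown here, in an ADME assay on the whole organism for pharmacokinetics, with Rattus norvegicus as the target (a lower number here means that the compound disappears faster, a higher number that the compound lasts longer), compound 1 `Cc1cc(C)c(NC(=O)c2sccc2S(=O)(=O)Nc2onc(C)c2Cl)c(-c2ncco2)c1` gives 5.3 h and holds the lower of the two numbers measured so far. Compound 2 `Cc1cc(C)c(NC(=O)c2sccc2S(=O)(=O)Nc2onc(C)c2Cl)c(C(=O)CS(C)(=O)=O)c1` gives 12.2 h with ((methylsulfonyl)methyl)carbonyl in place of 1,3-oxazol-2-yl on an aromatic carbon. That swap is the measured step of a 2.3-fold higher number from compound 1 to compound 2 (0.36 log units; beyond the scatter) and counts as modest. Compound 3 `C/C(=N\O)c1cc(C)cc(C)c1NC(=O)c1sccc1S(=O)(=O)Nc1onc(C)c1Cl` still awaits its measurement and changes the same place on the core of compound 1: a group of 4 heavy atoms (2 carbon, 1 nitrogen, 1 oxygen; no ring) in place of a group of 5 heavy atoms (3 carbon, 1 nitrogen, 1 oxygen; one five-membered aromatic ring with 2 hetero atoms), on an aromatic carbon on an aromatic carbon of a six-membered aromatic ring of carbon only. For the measured compounds named here, only one measured step bears on this change, and the entering group is not the one found in compound 2, so the guide is weak. Taking a 2.3-fold higher number from compound 1 to compound 2 (0.36 log units; beyond the scatter) as that guide, a rise smaller than that one is expected in this assay and it may stay inside the scatter. The expected step is a 1.4-fold higher number from compound 1 to compound 3 (0.15 log units; within the scatter) and remains an estimate. For compound 3 the estimated half-life is 7.5 h with an expected range from 3.5 h to 16 h in this measurement.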

Compound 3, half-life: 5.2 h
Compound 3: middle estimate off by 1.4-fold (0.16 log units), on the high side; the range from low to high includes it.
By their numbers in this assay, from the lowest: compounds 3 and 1 (each within the scatter of the next); then compound 2.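

In this assay, the step of a 1.0-fold lower number from compound 1 to compound 3 (0.01 log units; within the scatter) shows that this position can carry a group with no ring, one double bond and one hydrogen-bond donor and still read the same as with 1,3-oxazol-2-yl, so removing that five-membered aromatic ring need not shift the half-life. Having no ring is also not enough to match the number of compound 2, since a 2.3-fold lower number from compound 2 to compound 3 (0.37 log units; beyond the scatter) separates two groups that both lack a ring. Nothing measured here gives a reason for this difference between the groups.

The compounds shown leave open which part of the ((methylsulfonyl)methyl)carbonyl group goes with the higher number: its carbonyl, its sulfonyl or its greater length. From the compounds shown here alone, it also remains open whether a plain acetyl group, a simple amine or a carboxylic acid on this aromatic carbon would read with compound 2 or with the pair of compound 1 and compound 3.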